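The source may report more compounds than this note shows. Statements on the series, on what has been measured and on what is new or still open speak of the compounds shown alone.

Measured compounds:
Compound 1, `CC(C)n1ncc2c(C(=O)NCCCN(C)C)cc(C3CC3)nc21`, gives a value that is a limit of the assay: > 200000 nM.
Compound 2, `CNCCCNC(=O)c1cc(C2CC2)nc2c1cnn2C(C)C`, gives 281000 nM.
Compound 3, `CNCCNC(=O)c1cc(C)nc2c1cnn2C(C)C`, gives a value that is a limit of the assay: > 300000 nM.

All three were tested in an ADME assay on Vero cells (Chlorocebus sabaeus) for cytotoxicity, read by neutral red uptake, with a stated time of 3 days; a lower number here means that less compound is tolerated, a higher number that more compound is tolerated. The change from compound 1 to compound 2 is hydrogen in place of methyl on an amine nitrogen, and the step that the limit leaves unreadable from compound 1 to compound 2 cannot be sized because compound 1 sits at the limit of > 200000 nM in this assay, at which 1 of the 3 values shown sits. Compound 3 shares its own core with compound 4, `Cc1cc(C(=O)NCCN)c2cnn(C(C)C)c2n1`; how that core differs from the core of compound 1 is not broken down here. The change from compound 3 to compound 4 is hydrogen in place of methyl on an amine nitrogen. It is the same kind of change as that from compound 1 to compound 2, but the place is not identical: in compound 1 the amine nitrogen has two saturated chain carbons as its other neighbours, in compound 3 only one. Among the compounds with values here, compound 3 itself sits at the limit of > 300000 nM in this assay, at which 1 of the 3 values shown sits, so no measured step on its core is available. Compound 4 is expected to stay in the same region, with the expected step that the limit leaves unreadable from compound 3 to compound 4 resting on compound 2 at 281000 nM. Compound 4 is therefore estimated at 320000 nM, between 180000 nM and 600000 nM.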

Compound 4, half-maximal cytotoxic concentration: > 300000 nM
Compound 4: a limit, no number (the forecaster's own chance of this, stated with the estimate: 55%); the middle value is on the limit's open side.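

In this assay compound 4 gives a limit of the assay, > 300000 nM. Compound 3 stands at that same limit, so no step can be read between compound 3 and compound 4: the limit of > 300000 nM in this assay, at which 2 of the 4 values shown sit. The compounds shown leave open how far either compound lies past this limit, and whether hydrogen in place of methyl changes the read-out on this core.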